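Bromination of a Catechol Series: Cytotoxicity on DLD-1 Cells

The source may hold more compounds than are shown below. What is called first, only, known or untested is meant among the compounds shown, and "the series" means these compounds.

Compound 1 `COCc1cc(O)c(O)c(Br)c1`: 35300 nM
Compound 2 `CCOCc1cc(O)c(O)c(Br)c1`: 35100 nM
Compound 3 `COCc1cc(Br)c(O)c(O)c1Br`: 7270 nM

Of the compounds shown here, three have been measured in a functional assay on DLD-1 cells (Homo sapiens) for cytotoxicity, read by MTT assay, with a stated time of 96 h; on this read-out lower numbers stand for stronger inhibition and higher numbers for weaker inhibition. Compound 1 `COCc1cc(O)c(O)c(Br)c1` gives 35300 nM in this assay, and compound 2 `CCOCc1cc(O)c(O)c(Br)c1`, which differs from it by methyl in place of hydrogen on a saturated chain carbon bound to an oxygen on a saturated carbon, gives 35100 nM; the two lie within the scatter of each other, as a 1.0-fold lower number from compound 1 to compound 2 (0.00 log units; within the scatter) shows. Compound 3 `COCc1cc(Br)c(O)c(O)c1Br` gives 7270 nM in this assay, and the change from compound 1, (bromo in place of hydrogen on an aromatic carbon), brings a 4.9-fold lower number from compound 1 to compound 3 (0.69 log units; beyond the scatter).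

Compound 4 `CCOCc1cc(O)c(O)c(Br)c1Br` has not yet been measured. It differs from compound 2 by bromo in place of hydrogen on an aromatic carbon. Within the data shown here, this is the same kind of change as the one from compound 1 to compound 3, but not the same: in compound 3 the entering bromo sits ortho to a hydroxy group, ortho to a methoxymethyl group and para to a bromo group, whereas in compound 4 it sits ortho to a bromo group, ortho to an ethoxymethyl group and para to a hydroxy group. The two cores themselves differ by methyl in place of hydrogen on a saturated chain carbon bound to an oxygen on a saturated carbon.

Among the measured compounds shown here, the step in this assay from compound 2 to compound 4 is expected to be about a 4.4-fold lower number from compound 2 to compound 4 (0.64 log units; beyond the scatter), set beside the measured 4.9-fold lower number from compound 1 to compound 3 (0.69 log units; beyond the scatter), because the only precedent for adding a bromo group here is a 4.9-fold lower number from compound 1 to compound 3 (0.69 log units; beyond the scatter); the different surroundings of the new bromo in compound 4 leave this less certain. Compound 4 is therefore expected to give about 8000 nM in this assay, most likely between 3000 nM and 25000 nM.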

Compound 4, half-maximal inhibitory concentration: 13500 nM
Beside the measured number, compound 4's estimate is 1.7-fold (0.23 log units) below it, and the stated range covers the measured number.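

In this assay, bromo in place of hydrogen on an aromatic carbon brings a 2.6-fold lower number from compound 2 to compound 4 (0.41 log units; beyond the scatter), so on this second core the change again goes toward stronger inhibition. Set beside the earlier step, the two agree as closely as such steps can be told apart: the same change on two cores in this assay, a 4.9-fold lower number (0.69 log units; beyond the scatter) from compound 1 to compound 3 and a 2.6-fold lower number (0.41 log units; beyond the scatter) from compound 2 to compound 4, 1.9-fold (0.27 log units) apart, within the scatter of two such steps This shows that, across these two pairs, the change carries from the methoxymethyl core to the ethoxymethyl core in direction and, within the scatter, in size, but it does not show that the step is the same wherever the bromo enters, since the new bromo stands in different surroundings in the two pairs, and two pairs cannot separate the part played by those surroundings from the part played by the core.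

The compounds shown leave open whether chloro or iodo in the same place would bring a step of like size, and whether the change would hold on a core with a longer chain, such as butoxymethyl, or with an amine in place of the ether oxygen. They also leave open what happens to the step when a methoxy group stands in place of either hydroxy group.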